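A few compounds are considered here, and "the series" means these few. Any claim that something is new, unique, unknown or untested is made for them only; others in the source may bear on it.

Measured compounds:
Compound 1 `COc1ccc(OC)c(/C=N/NC(=O)Nc2ccc(Oc3ccnc(-c4nncn4CCN(C)C)c3)c(F)c2)c1` gives 6400 nM in a functional assay on U-87MG ATCC cells (Homo sapiens) for cytotoxicity, read by MTT assay, with a stated time of 72 h; on this read-out lower numbers stand for stronger inhibition and higher numbers for weaker inhibition.
Compound 2 `CN(C)CCn1cnnc1-c1cc(Oc2ccc(NC(=O)N/N=C/c3ccc(F)cc3)cc2F)ccn1` gives 2310 nM in this assay.
Compound 3 `CN(C)CCn1cnnc1-c1cc(Oc2ccc(NC(=O)N/N=C/c3c(Cl)cccc3Cl)cc2F)ccn1` gives > 100000 nM in this assay; this is a limit of the assay, not a number.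

Compound 3 therefore stands at the weak end of the three, sitting at the limit of > 100000 nM in this assay, at which 1 of the 3 values shown sits. Compound 4 `CN(C)CCn1cnnc1-c1cc(Oc2ccc(NC(=O)N/N=C/c3ccc(O)cc3O)cc2F)ccn1` keeps the shared core and changes only the ring on the carbon with a double bond to nitrogen: 2,4-dihydroxyphenyl in place of 2,6-dichlorophenyl on a carbon with a double bond to nitrogen.

Within the data shown here, two measured steps bear on this position. Replacing the 2,5-dimethoxyphenyl of compound 1 with 2,6-dichlorophenyl gave an at least 15-fold higher number from compound 1 to compound 3 (1.19 log units; beyond the scatter), and replacing the 4-fluorophenyl of compound 2 with the same 2,6-dichlorophenyl gave an at least 43-fold higher number from compound 2 to compound 3 (1.63 log units; beyond the scatter). Both show that 2,6-dichlorophenyl at this place is linked to a large loss of cytotoxic potency, while the two other rings sit in the low micromolar range. Removing the 2,6-dichlorophenyl again is thus expected to bring compound 4 back towards the numbers of compound 1 and compound 2, a step estimated as an at least 20-fold lower number from compound 3 to compound 4 (1.30 log units; beyond the scatter). On these data alone, the 2,4-dihydroxyphenyl is untested here, so the estimate for compound 4 is set between the values of compound 1 and compound 2, at 5000 nM, with a range from 1500 nM to 30000 nM.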

Compound 4, half-maximal inhibitory concentration: 15400 nM
Compound 4: middle estimate off by 3.1-fold (0.49 log units), on the low side; measured number inside the range.
By their numbers in this assay, from the lowest: compound 2; then compound 1; then compound 4. At a limit, above all of these: compound 3.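

Moving from the 2,6-dichlorophenyl to the 2,4-dihydroxyphenyl gives an at least 6.4-fold lower number from compound 3 to compound 4 (0.81 log units; beyond the scatter) in this assay, so a ring with two hydrogen-bond donors at this place keeps a measurable cytotoxic effect. The value of compound 3 is a limit and not a number, which means this step has a known minimum but no known full size: the limit of > 100000 nM in this assay, at which 1 of the 4 values shown sits. The recovery is only partial, however, since the new ring also gives a 6.7-fold higher number from compound 2 to compound 4 (0.82 log units; beyond the scatter) and a 2.4-fold higher number from compound 1 to compound 4 (0.38 log units; beyond the scatter), which shows that the ring on the carbon with a double bond to nitrogen still shifts the number measurably among the three rings that give values.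

With a single dihydroxyphenyl compound, the effect of each hydroxyl cannot be told apart, so a phenyl ring with one hydroxyl would be the direct next comparison. On these data alone, whether an amine or a carboxylic acid on this ring would sit nearer to the 4-fluorophenyl of compound 2 or nearer to the limit of compound 3 also stays open.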